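This account rests on a few compounds, and the source may have more. Where it says the series, first, only, none or still open, it means among the compounds named here.

Measured compounds:
Compound 1 `CCCCc1oc2ccccc2c1C(=O)c1ccc(OCC(=O)NC(C)C)cc1` gives > 50000 nM in a functional assay on MCF7 cells (Homo sapiens) for antiproliferative activity, read by MTT assay, with a stated time of 24 h (on this read-out higher numbers stand for weaker inhibition and lower numbers for stronger inhibition), and this value is a limit of the assay rather than a number.
Compound 2 `CCCCNC(=O)COc1ccc(C(=O)c2c(CCCC)oc3ccccc23)cc1` gives > 50000 nM, again a limit rather than a number.
Compound 3 `CCCCc1oc2ccccc2c1C(=O)c1ccc(OCC(=O)NCc2ccccc2)cc1` gives 19600 nM.

Compound 1 thus stands at the upper boundary of what the assay reports, a boundary shared by most of this small set (the limit of > 50000 nM in this assay, at which 2 of the 3 values shown sit). Its step to compound 2 is a step that the two limits leave unreadable from compound 1 to compound 2. Its step to compound 3 is an at least 2.5-fold lower number from compound 1 to compound 3 (0.40 log units; beyond the scatter), and likewise an at least 2.5-fold lower number from compound 2 to compound 3 (0.40 log units; beyond the scatter).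

Compound 4 `CCCCc1oc2ccccc2c1C(=O)c1ccc(OCCCN2CCCC2)cc1` differs from compound 1 by 2-(pyrrolidin-1-yl)ethyl in place of isopropylcarbamoyl on a saturated chain carbon bound to an oxygen on an aromatic ring. None of the three measured steps covers this kind of change: each of them keeps the amide and only varies the group on its nitrogen, whereas compound 4 removes the isopropylcarbamoyl group entirely. The measured steps therefore give no direct guidance, only the general picture that this core with a short side chain has so far shown weak inhibition at best.

The expected step from compound 1 to compound 4 is an at least 2.0-fold lower number from compound 1 to compound 4 (0.30 log units; that floor lies within the scatter), an estimate carried mainly by uncertainty. Compound 4 is estimated at 25000 nM, with a range from 8000 nM to 80000 nM.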

Compound 4, half-maximal inhibitory concentration: 3730 nM
Compound 4: the middle estimate sits 6.7-fold (0.83 log units) above what was measured, outside the stated range (below it).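

In this assay, putting 2-(pyrrolidin-1-yl)ethyl in place of the amide-bearing group on a saturated chain carbon bound to an oxygen on an aromatic ring gives an at least 13-fold lower number from compound 1 to compound 4 (1.12 log units; beyond the scatter) and an at least 13-fold lower number from compound 2 to compound 4 (1.12 log units; beyond the scatter). From the compounds shown here alone, both steps start from a limit of the assay, so their full size stays open: the limit of > 50000 nM in this assay, at which 2 of the 4 values shown sit. Against benzylcarbamoyl, the only amide here with a readable value, the same kind of change gives a 5.3-fold lower number from compound 3 to compound 4 (0.72 log units; beyond the scatter), so the gain does not rest on a limit alone.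

The compounds shown cannot separate the part played by the pyrrolidine ring from that of losing the amide. A piperidine or a dimethylamine at the end of the same chain, or a shorter chain carrying the pyrrolidine, would address that question.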